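The source may hold more compounds than are shown below. What is called first, only, known or untested is meant among the compounds shown, and "the series" means these compounds.

Measured so far in an in vitro assay on SH-SY5Y cells for displacement of a labelled ligand from Neuronal acetylcholine receptor; alpha3/beta4 (Homo sapiens); on this read-out higher numbers stand for weaker inhibition and lower numbers for stronger inhibition:
compound 1 `C1=C(c2cncnc2)CC2CNCC1C2` gives 58 nM
compound 2 `Clc1ccc(Oc2cncc(C3=CC4CNCC(C3)C4)c2)cc1` gives 40 nM

Compound 2 carries the lower of the two numbers, but its gap to compound 1 lies within the usual scatter, so no order between the two is claimed. Compound 3 `CC(C)Oc1cncc(C2=CC3CNCC(C2)C3)c1` has not been measured. Against compound 2 it shows (isopropyl in place of 4-chlorophenyl on an oxygen on an aromatic ring). Among the measured compounds shown here, no measured pair carries a change of this kind, so nothing here shows its effect. The estimate for compound 3 in this assay is 80 nM, with a range from 30 nM to 250 nM. The expected step, a 2.0-fold higher number from compound 2 to compound 3 (0.30 log units; within the scatter), is small, toward a higher number, and may well stay within the scatter.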

Compound 3, inhibition constant: 4.8 nM
Compound 3: the middle estimate sits 17-fold (1.22 log units) above what was measured; measured number below the stated range.
By their numbers in this assay, from the lowest: compound 3; then compounds 2 and 1 (each within the scatter of the next).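

Among the compounds shown here, on the oxygen on the aromatic ring, the group it carries matters: isopropyl in place of 4-chlorophenyl gives an 8.3-fold lower number from compound 2 to compound 3 (0.92 log units; beyond the scatter) in this assay, the first step beyond the scatter. At this position, the 4-chlorophenyl ring is therefore not required for a low number, and the smaller group without a ring does better. No measurement shown accounts for this step.

Open, as far as these compounds go, is whether the lower number is specific to isopropyl. Methyl, cyclopropyl and a longer chain such as n-butyl lie outside the compounds shown, as does an amine in place of the oxygen.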